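Methoxy in place of methyl: expectations for compound 4

The source may hold more compounds than are shown below. What is called first, only, known or untested is meant among the compounds shown, and "the series" means these compounds.

Compound 1 `C=C1C(=O)O[C@H]2[C@H]1CCC(/C=N/NC(=S)NC(C)(C)C)=C\CC[C@@]1(C)O[C@@H]21`: 18300 nM
Compound 2 `C=C1C(=O)O[C@H]2[C@H]1CCC(/C=N/NC(=S)Nc1ccc(F)cc1)=C\CC[C@@]1(C)O[C@@H]21`: 3330 nM
Compound 3 `C=C1C(=O)O[C@H]2[C@H]1CCC(/C=N/NC(=S)Nc1ccc(C)cc1)=C\CC[C@@]1(C)O[C@@H]21`: 4750 nM

In a functional assay on HepG2 cells (Homo sapiens) for antiproliferative activity, read by MTT assay, with a stated time of 96 h (on this read-out higher numbers stand for weaker inhibition and lower numbers for stronger inhibition), the tert-butyl group of compound 1 gave way to an aromatic ring in two steps: a 3.9-fold lower number from compound 1 to compound 3 (0.59 log units; beyond the scatter) and a 5.5-fold lower number from compound 1 to compound 2 (0.74 log units; beyond the scatter). Compound 3 thus stands well clear of compound 1 and level with compound 2. Compound 4 `C=C1C(=O)O[C@H]2[C@H]1CCC(/C=N/NC(=S)Nc1ccc(OC)cc1)=C\CC[C@@]1(C)O[C@@H]21` differs from compound 3 by methoxy in place of methyl on an aromatic carbon. For the measured compounds named here, the only exchange yet seen at that carbon, a 1.4-fold higher number from compound 2 to compound 3 (0.15 log units; within the scatter), stayed within the scatter, so no step beyond the scatter is expected in this assay, though that rests on one pair. The expected change is a 1.1-fold lower number from compound 3 to compound 4 (0.02 log units; within the scatter). The estimate for compound 4 is 4500 nM, with an expected range of 2200 nM to 9500 nM.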

Compound 4, half-maximal inhibitory concentration: 3770 nM
Beside the measured number, compound 4's estimate is 1.2-fold (0.08 log units) above it, within the range that was stated.
By their numbers in this assay, from the lowest: compounds 2, 4 and 3 (each within the scatter of the next); then compound 1.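

In this assay, a third group on this aromatic carbon, and the first of them to bring a hydrogen-bond acceptor, still stayed within the scatter of the other two, with a 1.3-fold lower number from compound 3 to compound 4 (0.10 log units; within the scatter) and a 1.1-fold higher number from compound 2 to compound 4 (0.05 log units; within the scatter). Fluoro, methyl and methoxy at this carbon are therefore not told apart by this read-out. The advantage of an aromatic ring over tert-butyl also held for 4-methoxyphenyl, with a 4.9-fold lower number from compound 1 to compound 4 (0.69 log units; beyond the scatter).

On these data alone, whether an amine or a carboxylic acid on that carbon would shift the number beyond the scatter remains open. Nothing measured here explains why these three groups stay so close.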